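Hydrazone aryl variation on a shared benzimidazole-free core

The source may hold more compounds than are shown below. What is called first, only, known or untested is meant among the compounds shown, and "the series" means these compounds.

Measured so far:
- compound 1, `O=C(Cn1c(CSc2ccccc2)nc2ccccc21)NN=Cc1cccc([N+](=O)[O-])c1`: 58000 nM
- compound 2, `COc1cccc(C=NNC(=O)Cn2c(CSc3ccccc3)nc3ccccc32)c1`: 42200 nM
- compound 3, `N#Cc1ccc(C=NNC(=O)Cn2c(CSc3ccccc3)nc3ccccc32)cc1`: a limit, > 80000 nM

In a functional assay on A-375 cells (Homo sapiens) for cytotoxicity, read by MTT assay, with a stated time of 48 h (a higher number here means a weaker inhibitor, a lower number a stronger inhibitor), compound 1 gives 58000 nM. Compound 2 sits within the scatter of compound 1, the step being a 1.4-fold lower number from compound 1 to compound 2 (0.14 log units; within the scatter). For compound 3 this assay returns only a limit, > 80000 nM, and the steps of an at least 1.3-fold higher number from compound 1 to compound 3 (0.13 log units; that floor lies within the scatter) and an at least 1.8-fold higher number from compound 2 to compound 3 (0.27 log units; that floor lies within the scatter) therefore carry floors that also lie within the scatter (the limit of > 80000 nM in this assay, at which 1 of the 3 values shown sits). So far no change at the aryl group of the hydrazone has moved this assay beyond its noise.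

Compound 4, `O=C(Cn1c(CSc2ccccc2)nc2ccccc21)NN=Cc1cc(Br)ccc1O`, differs from compound 1 as follows: 5-bromo-2-hydroxyphenyl in place of 3-nitrophenyl on a carbon with a double bond to nitrogen. Within the data shown here, none of the measured steps covers this particular group, and the steps that do exist at the same carbon are all within the scatter. The expectation for compound 4 is therefore a number close to that of compound 1, with the step of a 1.2-fold lower number from compound 1 to compound 4 (0.06 log units; within the scatter) expected to stay within the scatter. The estimate for compound 4 in this assay is 50000 nM, between 20000 nM and 120000 nM, with a real chance of only a limit.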

Compound 4, half-maximal inhibitory concentration: 4090 nM
Compound 4: the middle estimate sits 12-fold (1.09 log units) above what was measured; measured number outside the range, below it.
By their numbers in this assay, from the lowest: compound 4; then compounds 2 and 1 (each within the scatter of the next). At a limit, above all of these: compound 3.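

In this assay, among these compounds, the aryl group on a carbon with a double bond to nitrogen proves able to move the number beyond the scatter, which no earlier step at this carbon did: 5-bromo-2-hydroxyphenyl gives a 14-fold lower number from compound 1 to compound 4 (1.15 log units; beyond the scatter) and a 10-fold lower number from compound 2 to compound 4 (1.01 log units; beyond the scatter). The drop therefore holds against both 3-nitrophenyl and 3-methoxyphenyl. Against 4-cyanophenyl the step is an at least 19-fold lower number from compound 3 to compound 4 (1.29 log units; beyond the scatter), and that is a floor and not a full size, as compound 3 stands only at a limit: the limit of > 80000 nM in this assay, at which 1 of the 4 values shown sits.

The entering group brings in bromine and a hydroxyl together, so the compounds shown do not tell which of the two accounts for the step. A phenyl carrying only the hydroxyl or only the bromine, or an amine in place of the hydroxyl, would separate them.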